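Tracing a methyl for phenyl swap on a benzimidazole chain

The source may report more compounds than this note shows. Statements on the series, on what has been measured and on what is new or still open speak of the compounds shown alone.

Three compounds have been measured in a functional assay on RPMI 8402 cells (Homo sapiens) for cytotoxicity; a lower number here means a stronger inhibitor, a higher number a weaker inhibitor:
Compound 1 `CCc1nc2cc(-c3nc4cc(-c5nc6cc(-c7ccccc7)ccc6[nH]5)ccc4[nH]3)ccc2[nH]1` gives 110 nM.
Compound 2 `c1ccc(-c2ccc3[nH]c(-c4ccc5[nH]c(-c6ccc7[nH]cnc7c6)nc5c4)nc3c2)cc1` gives 90 nM.
Compound 3 `c1ccc(-c2ccc3[nH]c(-c4ccc5[nH]c(-c6ccc7[nH]c(-c8ccccc8)nc7c6)nc5c4)nc3c2)cc1` gives 60 nM.

Compound 3 has the lowest of the three numbers, but its gaps to the others are small: a 1.5-fold lower number from compound 2 to compound 3 (0.18 log units; within the scatter) and a 1.8-fold lower number from compound 1 to compound 3 (0.26 log units; within the scatter) are both within the scatter, so the three compounds cannot be told apart on these numbers.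

Compound 4 `Cc1nc2cc(-c3nc4cc(-c5nc6cc(-c7ccccc7)ccc6[nH]5)ccc4[nH]3)ccc2[nH]1` has not yet been measured. It differs from compound 3 in one place: methyl in place of phenyl on an aromatic carbon. The two measured steps that bear on this change are those that put the phenyl in: a 1.8-fold lower number from compound 1 to compound 3 (0.26 log units; within the scatter) and a 1.5-fold lower number from compound 2 to compound 3 (0.18 log units; within the scatter). Both are within the scatter, which means that at this position hydrogen, ethyl and phenyl gave numbers that cannot be distinguished. Methyl, a one-carbon group, sits between hydrogen and ethyl in size, so nothing among the measured steps points to a change beyond the scatter in this assay; at most a slightly higher number, like that of compound 1 or compound 2, is expected.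

Compound 4 is therefore expected to give about 90 nM, in a range from 45 nM to 180 nM, a step of a 1.5-fold higher number from compound 3 to compound 4 (0.18 log units; within the scatter).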

Compound 4, half-maximal inhibitory concentration: 110 nM
Beside the measured number, compound 4's estimate is 1.2-fold (0.09 log units) below it; the range from low to high includes it.
By their numbers in this assay, from the lowest: compounds 3, 2, 1 and 4 (each within the scatter of the next).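

In this assay, methyl now joins hydrogen, ethyl and phenyl on this aromatic carbon between two ring nitrogen atoms, and it too cannot be told apart from them: there is a 1.8-fold higher number from compound 3 to compound 4 (0.26 log units; within the scatter) and a 1.2-fold higher number from compound 2 to compound 4 (0.09 log units; within the scatter) and also no change at the digits printed from compound 1 to compound 4 (within the scatter) in this series. Swapping a six-carbon aromatic ring for a single carbon therefore stays within the scatter, as does removing one carbon from ethyl, so across these four compounds no group tried at this position moves the number beyond the scatter. Nothing available here offers an explanation for so flat a result.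

The groups shown at this position contain only carbon and hydrogen, so it remains open whether an amine or a carboxylic acid there would give a clearly different number. All four compounds also share a phenyl elsewhere on the core, so what that group contributes to the number cannot be read from them.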